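Series notes: 4-methylphenyl for 3-bromophenyl on the chain

The compounds below may be only part of what the source reports. "The series", "measured", "known", "first", "only" and "open" are said of these compounds alone.

Of the compounds shown here, two have been measured in an assay for inhibition of Polyunsaturated fatty acid 5-lipoxygenase (Homo sapiens), read by spectrophotometry, tested at 10 uM, in the presence of a further agent that is not named here; a lower number here means less inhibition, a higher number more inhibition at the concentration tested (going by the name of the read-out). Compound 1 `Cc1nc(NC(=O)c2ccccc2)sc1C(=O)/C=C/c1ccc(F)cc1` gives 98%. Compound 2 `Cc1nc(NC(=O)c2ccccc2)sc1C(=O)/C=C/c1cccc(Br)c1` gives 42.5% in this assay. Going by the values given here, compound 2 thus stands lowest of the two numbers; the only measured step, a number 55.5 percentage points lower from compound 1 to compound 2 (beyond the scatter), is large and is the sole guide for what follows.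

Compound 3 `Cc1ccc(/C=C/C(=O)c2sc(NC(=O)c3ccccc3)nc2C)cc1` has not yet been measured. It differs from compound 2 in this way: 4-methylphenyl in place of 3-bromophenyl on a double-bonded chain carbon bound to a double-bonded chain carbon. Compound 3 thus carries 4-methylphenyl where compound 1 carries 4-fluorophenyl and compound 2 carries 3-bromophenyl. The step of a number 55.5 percentage points lower from compound 1 to compound 2 (beyond the scatter) bears directly on this change, since it shows how much was lost when 3-bromophenyl replaced 4-fluorophenyl. Among the compounds with values here, removing 3-bromophenyl again is therefore expected to recover a good part of that loss, though no step between 4-methylphenyl and 4-fluorophenyl is known, so the size is uncertain. The expected step in this assay is a number 29.5 percentage points higher from compound 2 to compound 3 (beyond the scatter), upward and beyond the scatter. Compound 3 is estimated at 72% in this assay, with a range from 40% to 97%.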

Compound 3, a percentage reported as inhibition, at one concentration (the size of the read-out at that concentration, not a potency): 75.1%
For compound 3 the middle estimate is 3.1 percentage points below the measured one; the measured number falls inside the stated range.
By their numbers in this assay, from the lowest: compound 2; then compound 3; then compound 1.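

In this assay, 4-methylphenyl in place of 3-bromophenyl gives a number 32.6 percentage points higher from compound 2 to compound 3 (beyond the scatter) and so shows that the low number of compound 2 does not follow from every departure from 4-fluorophenyl at this place on the chain. Methyl in place of fluoro on an aromatic carbon still gives a number 22.9 percentage points lower from compound 1 to compound 3 (beyond the scatter), so this place also responds to a change of the group on the ring while the group's ring position in the name stays the same, although this loss is only modest. No measurement offered here accounts for either step.

The compounds shown leave open whether the low number of compound 2 goes with the bromine or with its ring position, since compound 2 and compound 3 differ in both; 4-bromophenyl and 3-methylphenyl at the same place on the chain would separate the two. Also open, on these data alone, is how a methoxy group, an amine or a carboxylic acid on this phenyl ring would stand against the fluoro and methyl groups.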